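Chloro to fluoro on the benzylidene ring: expected growth inhibition

A few compounds are considered here, and "the series" means these few. Any claim that something is new, unique, unknown or untested is made for them only; others in the source may bear on it.

Measured compounds:
compound 1, `O=C1NC(=S)/C(=C/c2ccccc2Br)S1`, 16.2%
compound 2, `O=C1NC(=S)/C(=C/c2cccc(Cl)c2)S1`, 11.2%
compound 3, `O=C1NC(=S)/C(=C/c2ccccc2Cl)S1`, 19.9%

In a functional assay on NCI-H292 cells (Homo sapiens) for cytotoxicity, read by MTT assay, with a stated time of 72 h, tested at 2.5 ug/mL (a lower number here means less inhibition of growth, a higher number more inhibition of growth at the concentration tested), compound 2 stands at the low end of the three numbers, but compound 1 and compound 3 both lie within the usual scatter of it. Compound 4, `O=C1NC(=S)/C(=C/c2cccc(F)c2)S1`, differs from compound 2 by fluoro in place of chloro on an aromatic carbon. For the measured compounds named here, the one measured step that bears on this, a halogen swapped for another halogen on the same ring, is a number 3.7 percentage points higher from compound 1 to compound 3 (within the scatter), within the scatter. A similar outcome is therefore expected here: a step of a number 0.8 percentage points higher from compound 2 to compound 4 (within the scatter), none beyond the scatter. Compound 4 is estimated at 12%, with a range of 2% to 24%.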

Compound 4, percent growth inhibition at one concentration: 3.43%
Compound 4: the middle estimate sits 8.6 percentage points above what was measured, and the stated range covers the measured number.
By their numbers in this assay, from the lowest: compounds 4, 2, 1 and 3 (each within the scatter of the next, the first and the last beyond it).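

At this place, on an aromatic carbon meta to a group of 8 heavy atoms, fluoro in place of chloro in this assay gives a number 7.8 percentage points lower from compound 2 to compound 4 (within the scatter). Taken with the earlier halogen swap, a number 3.7 percentage points higher from compound 1 to compound 3 (within the scatter), this means that neither exchange of one halogen for another can be told apart from the scatter. No available evidence bears on this result. On these data alone, whether an amine, a carboxylic acid or a methoxy group at this place would move growth inhibition beyond the scatter remains open.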